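Chloro in Place of Methyl in Compound 3

The source may hold more compounds than are shown below. What is called first, only, known or untested is meant among the compounds shown, and "the series" means these compounds.

Readings so far in an ADME assay on microsomes from liver (Mus musculus, strain CD1) for metabolic stability (on this read-out lower numbers stand for a shorter-lived compound and higher numbers for a longer-lived compound), are these:
Compound 1 `COc1cc(N2C(=O)C3(CCC3)N(c3ccc(OC4CCN(C)CC4)nc3)C2=S)cnc1C#N` with 2.25 h as its half-life
Compound 2 `CN1CCC(Oc2ccc(N3C(=S)N(c4cnc(C#N)c(C(F)(F)F)c4)C(=O)C34CCC4)cc2)CC1` with 1.55 h as its half-life
Compound 3 `Cc1cc(N2C(=O)C3(CCC3)N(c3ccc(OC4CCNCC4)nc3)C2=S)cnc1C#N` with > 3 h as a limit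

Compound 1 and compound 2 lie within the usual scatter of each other. For compound 3 the reading > 3 h is a limit of this assay and not a number, which leaves its exact standing among the three open.

Compound 4 `N#Cc1ncc(N2C(=O)C3(CCC3)N(c3ccc(OC4CCNCC4)nc3)C2=S)cc1Cl` differs from compound 3 by one group, (chloro in place of methyl on an aromatic carbon), with chloro in place of methyl on an aromatic carbon, ortho to a cyano group. The same difference reads 6-cyano-5-methylpyridin-3-yl to 5-chloro-6-cyanopyridin-3-yl.

Among the compounds with values here, none of the measured compounds shows this exchange directly. What is expected in this assay is a step within the scatter, with no firm direction, and the estimated step is a number no higher from compound 3 to compound 4 (the limit leaves the size open) on this evidence. For compound 4 the estimated value is 3 h with an expected range of 1.6 h to 5.5 h in this read-out.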

Compound 4, half-life: > 3 h
Compound 4: only a limit was reported (the forecaster's own chance of this, stated with the estimate: 45%); the middle value lies on the limit itself.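

Compound 4 reads > 3 h in this assay, which is a limit and not a number. Compound 3 also stands at a limit, and no step can be read between compound 3 and compound 4. From the compounds shown here alone, what chloro in place of methyl does to the half-life stays open.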